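Aryl swap at the hydrazone end: compound 3 to compound 4

This account rests on a few compounds, and the source may have more. Where it says the series, first, only, none or still open, it means among the compounds named here.

The series keeps one shared core and varies the aryl group on the carbon with a double bond to nitrogen. In a functional assay on HT-29 cells (Homo sapiens) for cytotoxicity, read by MTT assay, with a stated time of 72 h (a lower number here means a stronger inhibitor, a higher number a weaker inhibitor), compound 1 `CN(C)CCn1cnnc1-c1cc(Oc2ccc(NC(=O)N/N=C/c3ccc(Cl)cc3)cc2F)ccn1` gives 530 nM, compound 2 `CN(C)CCn1cnnc1-c1cc(Oc2ccc(NC(=O)N/N=C/c3cccc(Cl)c3Cl)cc2F)ccn1` gives 130 nM, and compound 3 `CN(C)CCn1cnnc1-c1cc(Oc2ccc(NC(=O)N/N=C/c3cc(Br)c(O)c(Br)c3)cc2F)ccn1` gives 2670 nM. Compound 3 stands at the highest number of the three: a 5.0-fold higher number from compound 1 to compound 3 (0.70 log units; beyond the scatter) and a 21-fold higher number from compound 2 to compound 3 (1.31 log units; beyond the scatter), both beyond the scatter, while the move a 4.1-fold lower number from compound 1 to compound 2 (0.61 log units; beyond the scatter) runs the other way.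

Compound 4 `Cc1cc(/C=N/NC(=O)Nc2ccc(Oc3ccnc(-c4nncn4CCN(C)C)c3)c(F)c2)cc(C)c1O` is not yet measured. It differs from compound 3 in one place: 4-hydroxy-3,5-dimethylphenyl in place of 3,5-dibromo-4-hydroxyphenyl on a carbon with a double bond to nitrogen. Among the measured compounds shown here, no measured step tests this exact change; the two steps that lead into compound 3 both replace a chlorophenyl by the 3,5-dibromo-4-hydroxyphenyl group, so they show only that this group carries the highest number so far, not what bromine against methyl on the same ring does. The hydroxy group is kept, so the change is judged smaller than the steps into compound 3. The expectation for compound 4 in this assay is a step of a 1.5-fold lower number from compound 3 to compound 4 (0.17 log units; within the scatter), with no direction held firmly. Compound 4 is estimated at 1800 nM, in the range 600 nM to 5500 nM.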

Compound 4, half-maximal inhibitory concentration: 1220 nM
Beside the measured number, compound 4's estimate is 1.5-fold (0.17 log units) above it; measured number inside the range.
By their numbers in this assay, from the lowest: compound 2; then compound 1; then compound 4; then compound 3.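

In this assay, replacing 3,5-dibromo-4-hydroxyphenyl with 4-hydroxy-3,5-dimethylphenyl on a carbon with a double bond to nitrogen gives a 2.2-fold lower number from compound 3 to compound 4 (0.34 log units; beyond the scatter) with the hydroxy group kept, so bromine against methyl on this ring now has a readable effect, and a modest one. Among the compounds shown here, the dimethyl ring does not bring the number down to that of either chlorinated ring, as a 2.3-fold higher number from compound 1 to compound 4 (0.36 log units; beyond the scatter) and a 9.4-fold higher number from compound 2 to compound 4 (0.97 log units; beyond the scatter) show, and across these four compounds both hydroxy-bearing rings give higher numbers than both chlorinated rings, with no compound going against this. No measurement at hand bears on the reason for these differences.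

Going by these compounds, what remains open is whether the hydroxy group or the two groups that accompany it on the ring drive the higher numbers. A 3,5-dimethylphenyl ring without the hydroxy group, or one with a methoxy or an amino group in its place, would separate these contributions, and a 2,3-dimethylphenyl ring would test whether the low number of compound 2 depends on chlorine.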